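Lengthening the chain on the ring nitrogen of compound 3

The compounds below may be only part of what the source reports. "The series", "measured", "known", "first", "only" and "open" are said of these compounds alone.

Compound 3 `C=CCN1CCCC(/C=C/c2ccccc2)C1` belongs to a small set of three piperidine-based compounds tested in an assay on isolated protein for binding affinity to Sigma non-opioid intracellular receptor 1 (Rattus norvegicus); a lower number here means a stronger inhibitor, a higher number a weaker inhibitor. In this assay compound 3 gives 4 nM, the second highest of the three numbers. Compound 1 `CC(C)=CCN1CCCC(/C=C\c2ccccc2)C1` gives 1 nM and compound 2 `C(=C\C1CCCN(CCC2CCCCC2)C1)\c1ccccc1` gives 7 nM; compound 3 and compound 2 lie within the scatter of each other, while compound 1 lies beyond it on the stronger side. Within the data shown here, the only single-point step among the measured compounds, a 7.0-fold higher number from compound 1 to compound 2 (0.85 log units; beyond the scatter), concerns the same position but exchanges an unsaturated branch for a saturated ring, so it bears only loosely on the present question.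

Compound 4 `C=CCCCN1CCCC(/C=C/c2ccccc2)C1` differs from compound 3 by but-3-en-1-yl in place of vinyl on a saturated chain carbon bound to an amine nitrogen in a ring. The chain grows by two carbons while the double bond is kept. Among the measured compounds shown here, with no matching step available, a modest change is expected, if any: a 1.3-fold higher number from compound 3 to compound 4 (0.10 log units; within the scatter). Compound 4 is therefore estimated at 5 nM, with a range from 2 nM to 15 nM.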

Compound 4, half-maximal inhibitory concentration: 12 nM
The estimate for compound 4 lay 2.4-fold (0.38 log units) below the measured number; the range from low to high includes it.
By their numbers in this assay, from the lowest: compound 1; then compounds 3, 2 and 4 (each within the scatter of the next, the first and the last beyond it).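

Among these compounds, until now, the only step at this position exchanged an unsaturated branch for a saturated ring, so it could not separate chain length from other changes. Here the double bond stays and only the chain grows: but-3-en-1-yl in place of vinyl on a saturated chain carbon bound to an amine nitrogen in a ring gives a 3.0-fold higher number from compound 3 to compound 4 (0.48 log units; beyond the scatter) in this assay. Lengthening alone therefore moves the number beyond the scatter, though only modestly, and nothing available explains why this happens.

Two chain lengths cannot show whether the number keeps rising along the series, which a longer chain such as hex-5-en-1-yl would test. On these data alone, it also remains open whether the double bond matters at this length, a question that a saturated butyl chain would address.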